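The source may report more compounds than this note shows. Statements on the series, on what has been measured and on what is new or still open speak of the compounds shown alone.

Series in a functional assay on HCT-116 cells (Homo sapiens) for antiproliferative activity, read by MTT assay, with a stated time of 72 h; on this read-out higher numbers stand for weaker inhibition and lower numbers for stronger inhibition:
- Compound 1 `C=CC(=O)N(Cc1cc(C)no1)c1nc(-c2ccccc2OC)cs1`: > 30000 nM, a limit
- Compound 2 `C=CC(=O)N(Cc1cc(C)no1)c1nc(-c2ccccc2O)cs1`: > 30000 nM, a limit
- Compound 3 `C=CC(=O)N(Cc1cc(C)no1)c1nc(-c2ccc(F)cc2O)cs1`: not yet measured

Compound 2 has no numerical value, and its > 30000 nM is only a limit. For the measured compounds named here, compound 1 offers no firmer reference, as the series so far rests on (the limit of > 30000 nM in this assay, at which 2 of the 2 values shown sit). Going by the values given here, the one measured step is a step that the two limits leave unreadable from compound 1 to compound 2, so it provides no size to carry forward.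

Compound 3 differs from compound 2 by fluoro in place of hydrogen on an aromatic carbon, in words fluoro in place of hydrogen on an aromatic carbon. With no readable step behind it, no direction can be argued in this assay, and another result at the limit is the likeliest expectation. The expected size is a number no higher from compound 2 to compound 3 (the limit leaves the size open). For compound 3 the estimate is 30000 nM, with an expected range of 8000 nM to 60000 nM.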

Compound 3, half-maximal inhibitory concentration: > 30000 nM
Compound 3 ended at the assay's limit (the forecaster's own chance of this, stated with the estimate: 70%); the middle value sits exactly at the limit.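

In this assay compound 3 gives > 30000 nM, a limit and not a number. For the compounds shown here, no step among compound 1, compound 2 and compound 3 can be read, as all rest on one limit: the limit of > 30000 nM in this assay, at which 3 of the 3 values shown sit. The compounds shown leave open whether 2-methoxyphenyl, 2-hydroxyphenyl and 4-fluoro-2-hydroxyphenyl differ in antiproliferative activity at all.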